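Chloro for methyl on the pyrazoline aryl: cytotoxicity notes

The source may report more compounds than this note shows. Statements on the series, on what has been measured and on what is new or still open speak of the compounds shown alone.

Three sulfonamides of one core have been run in an ADME assay on Vero 76 cells (Chlorocebus sabaeus) for cytotoxicity, read by MTT assay, with a stated time of 96 h; on this read-out higher numbers stand for lower toxicity in this test and lower numbers for higher toxicity in this test. Compound 1 `Cc1cccc(C2CC(c3ccc(Oc4ccccc4)cc3)=NN2c2ccc(S(N)(=O)=O)cc2)c1` gives 81000 nM in this assay. Compound 2 `Cc1ccc(C2CC(c3ccc(OCc4ccccc4)cc3)=NN2c2ccc(S(N)(=O)=O)cc2)cc1` gives 100000 nM, and compound 3 `Cc1cccc(C2CC(c3ccc(OCc4ccccc4)cc3)=NN2c2ccc(S(N)(=O)=O)cc2)c1` gives 100000 nM. Compound 1 stands with its number inside the scatter of both compound 2 and compound 3, so the three are not separated in this assay: the step of a 1.2-fold higher number from compound 1 to compound 3 (0.09 log units; within the scatter) and the step of no change at the digits printed from compound 2 to compound 3 (within the scatter) are both within the scatter.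

Compound 4 `NS(=O)(=O)c1ccc(N2N=C(c3ccc(Oc4ccccc4)cc3)CC2c2cccc(Cl)c2)cc1` is the next member. It differs from compound 1 by chloro in place of methyl on an aromatic carbon; cut one bond further out, the change reads 3-methylphenyl to 3-chlorophenyl. Going by the values given here, no measured step replaces methyl with chloro, so nothing bears on it directly. The closest comparison is the step from compound 2 to compound 3, where the methyl was moved on the same ring and the read-out did not shift, and the step from compound 1 to compound 3, also within the scatter. On that basis no step beyond the scatter is expected in this assay.

For compound 4 the expected value is 90000 nM, with a range from 45000 nM to 180000 nM, which means an estimated step of a 1.1-fold higher number from compound 1 to compound 4 (0.05 log units; within the scatter).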

Compound 4, half-maximal cytotoxic concentration: 88000 nM
Compound 4: middle estimate off by 1.0-fold (0.01 log units), on the high side; the range from low to high includes it.
By their numbers in this assay, from the lowest: compounds 1, 4, 2 and 3 (each within the scatter of the next).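

In this assay, going by these compounds alone, the 3-methylphenyl to 3-chlorophenyl change gives a 1.1-fold higher number from compound 1 to compound 4 (0.04 log units; within the scatter) and is the first measured replacement of the group on this aromatic carbon, as the earlier steps at this ring only moved the methyl. That earlier move gave no change at the digits printed from compound 2 to compound 3 (within the scatter) on the benzyl-on-oxygen compounds, so neither moving the methyl nor replacing it with chloro has produced a step beyond the scatter on this ring, although the replacement has been read only with the phenyl on oxygen of compound 1. No measurement at hand offers an explanation for this result.

On these data alone, whether the read-out stays within the scatter with a group of another kind on this carbon, such as an amine, a carboxylic acid or a longer alkyl chain, remains open. Also open, as far as these compounds go, is whether the same replacement behaves alike with benzyl on the oxygen, since the 3-chlorophenyl group appears here only with phenyl on the oxygen, and so the four compounds show no substitution on this ring that separates one compound from another in this test.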